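The source may report more compounds than this note shows. Statements on the series, on what has been measured and on what is new or still open speak of the compounds shown alone.

Working notes on the series, read in a functional assay on CCRF-CEM cells (Homo sapiens), read by MTT assay, with a stated time of 72 h; on this read-out lower numbers stand for stronger inhibition and higher numbers for weaker inhibition. Compound 1 (`Cc1nc(N)c2c(-c3ccsc3)cn([C@@H]3O[C@H](CO)[C@@H](O)[C@H]3O)c2n1`) gives only a limit, > 20000 nM. Compound 2 (`Cc1nc(N)c2c(-c3cc4ccccc4o3)cn([C@@H]3O[C@H](CO)[C@@H](O)[C@H]3O)c2n1`) also gives only a limit, > 20000 nM. Compound 3 (`C#Cc1cn([C@@H]2O[C@H](CO)[C@@H](O)[C@H]2O)c2nc(C)nc(N)c12`) likewise gives only a limit, > 20000 nM, and so has no numeric standing of its own. The three results coincide at the limit of > 20000 nM in this assay, at which 3 of the 3 values shown sit.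

The change to compound 4 (`Cc1nc(N)c2c(I)cn([C@@H]3O[C@H](CO)[C@@H](O)[C@H]3O)c2n1`) puts iodo in place of ethynyl on an aromatic carbon.

Three measured exchanges on an aromatic carbon bear on this change: a step that the two limits leave unreadable from compound 1 to compound 2, a step that the two limits leave unreadable from compound 1 to compound 3 and a step that the two limits leave unreadable from compound 2 to compound 3. None has a readable size, so none offers a size or direction to carry over. In this assay, no step beyond the scatter is therefore expected in either direction, though a number under the limit is not ruled out. The expectation rests on compound 3 and its limit of > 20000 nM. The expected change is a number no higher from compound 3 to compound 4 (the limit leaves the size open). Compound 4 is estimated at 20000 nM, with an expected range of 6000 nM to 40000 nM.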

Compound 4, half-maximal inhibitory concentration: 9030 nM
For compound 4 the middle estimate is 2.2-fold (0.35 log units) above the measured one, within the range that was stated.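

In this assay, iodo is the only group shown on this aromatic carbon that gives a number rather than a limit, and that number opens three readable steps: an at least 2.2-fold lower number from compound 3 to compound 4 (0.34 log units; beyond the scatter), an at least 2.2-fold lower number from compound 2 to compound 4 (0.34 log units; beyond the scatter) and an at least 2.2-fold lower number from compound 1 to compound 4 (0.34 log units; beyond the scatter). On these data alone, all three start from a limit, so each gives only a minimum size and the full size of the change stays open. Ethynyl, thiophen-3-yl and 1-benzofuran-2-yl cannot be ordered among themselves, and the steps between them cannot be read: the limit of > 20000 nM in this assay, at which 3 of the 4 values shown sit.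

The compounds shown leave open whether a chloro or bromo group, an amine or a carboxylic acid on this carbon would also give a number under the limit. With only compound 4 giving a number, no trend across groups at this position can yet be stated.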